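This account rests on a few compounds, and the source may have more. Where it says the series, first, only, none or still open, it means among the compounds named here.

Compound 1 `CCCCCCCc1cn(C(c2ccccc2)c2cc3cc(Br)ccc3nc2OC)nn1` was tested in an ADME assay on PC-3 cells (Homo sapiens) for cytotoxicity, read by sulforhodamine B assay, with a stated time of 48 h, tested at 10 uM (a higher number here means more inhibition at the concentration tested (going by the name of the read-out), a lower number less inhibition), and gives 4.42%, the lowest of the three numbers available, though its steps to the others stay within the scatter: compound 2 `COc1nc2ccc(Br)cc2cc1C(c1ccccc1)n1cc(-c2ccccc2F)nn1` gives 13.4% and compound 3 `CCCCCc1cn(C(c2ccccc2)c2cc3cc(Br)ccc3nc2OC)nn1` gives 11.4%. The change to compound 4 `COc1nc2ccc(Br)cc2cc1C(c1ccccc1)n1cc(-c2ccc(OC(F)(F)F)cc2)nn1` is 4-(trifluoromethoxy)phenyl in place of heptyl on an aromatic carbon. The closest measured steps are a number 9 percentage points higher from compound 1 to compound 2 (within the scatter) and a number 2 percentage points lower from compound 2 to compound 3 (within the scatter), both swaps between a chain and an aryl group at this position, and neither moved the read-out beyond the scatter. A step of similar size, or none beyond the scatter, is therefore expected in this assay for compound 4, estimated as a number 5.6 percentage points higher from compound 1 to compound 4 (within the scatter). Compound 4 is thus expected to give 10%, within -2% to 25%.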

Compound 4, a percentage reported as inhibition, at one concentration (the size of the read-out at that concentration, not a potency): 21.6%
For compound 4 the middle estimate is 11.6 percentage points below the measured one; low and high end bracket the measured number.
By their numbers in this assay, from the lowest: compounds 1, 3, 2 and 4 (each within the scatter of the next, the first and the last beyond it).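

In this assay, among the compounds shown here, 4-(trifluoromethoxy)phenyl gives the first steps beyond the scatter at this aromatic carbon, both modest: against heptyl (a number 17.2 percentage points higher from compound 1 to compound 4 (beyond the scatter)) and against pentyl (a number 10.2 percentage points higher from compound 3 to compound 4 (beyond the scatter)). An aryl group in place of a chain is not enough on its own, since compound 2 stays within the scatter of compound 1 and compound 3, and the step from 2-fluorophenyl also stays within it (a number 8.2 percentage points higher from compound 2 to compound 4 (within the scatter)). Nothing available explains this difference between the two aryl groups. From the compounds shown here alone, it remains open how unsubstituted phenyl or 4-methoxyphenyl would compare at this carbon. Going by these compounds, a carboxylic acid or an amine on the chain is equally open.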